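Methoxy to Ethoxy: From Compound 2 toward Compound 3

The source may hold more compounds than are shown below. What is called first, only, known or untested is meant among the compounds shown, and "the series" means these compounds.

Measured so far:
compound 1 `CCOc1c(-c2occ(C)c2C(=O)OC)ccc2c(CC)cccc12` — 1.9 ug/mL
compound 2 `CCc1cccc2c(OC)c(-c3occ(C)c3COC(C)=O)ccc12` — > 10 ug/mL

In a functional assay on SK-BR-3 cells (Homo sapiens) for cytotoxicity, read by MTT assay, with a stated time of 72 h (a lower number here means that less compound is needed, a higher number that more compound is needed for the effect), compound 1 gives 1.9 ug/mL. For compound 2 this assay reports no number but only a limit, > 10 ug/mL. Compound 2 therefore stands at the limit of > 10 ug/mL in this assay, at which 1 of the 2 values shown sits, so its true value is not fixed.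

Compound 3 `CCOc1c(-c2occ(C)c2COC(C)=O)ccc2c(CC)cccc12` is not yet measured in this assay. It differs from compound 2 by methyl in place of hydrogen on a saturated chain carbon bound to an oxygen on an aromatic ring. Among the compounds with values here, no step between measured compounds covers this change, so its size is unknown. The step from compound 2 to compound 3 is expected to be modest, an at least 1.4-fold lower number from compound 2 to compound 3 (0.15 log units; that floor lies within the scatter), most likely toward a lower number, though a result within the scatter cannot be excluded. Compound 3 is accordingly estimated at 7 ug/mL, with a range from 2 ug/mL to 20 ug/mL. A fair chance remains that compound 3 again returns only a limit.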

Compound 3, concentration for half-maximal effect: > 10 ug/mL
Compound 3 was reported as a limit; the forecaster's own chance of this, stated with the estimate: 40%; middle value at least 1.4-fold (0.15 log units) from the limit.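

In this assay compound 3 also returns only a limit, > 10 ug/mL, as compound 2 did, so the step from methoxy to ethoxy cannot be read: the limit of > 10 ug/mL in this assay, at which 2 of the 3 values shown sit.

Within the data shown here, with the ethoxy group held in place, acetoxymethyl in place of methoxycarbonyl on an aromatic carbon gives an at least 5.2-fold higher number from compound 1 to compound 3 (0.72 log units; beyond the scatter), the first readable step. Ethoxy therefore does not by itself return a number: of the compounds shown, only compound 1, which carries methoxycarbonyl, has one.

On these data alone, the true values of compound 2 and compound 3 stay open, and so does any effect of methoxy against ethoxy when methoxycarbonyl is present. Also open, as far as these compounds go, is how a carboxylic acid or a primary amide would compare with methoxycarbonyl at that aromatic carbon, and how a propoxy group would compare with ethoxy.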